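The source may hold more compounds than are shown below. What is called first, only, known or untested is meant among the compounds shown, and "the series" means these compounds.

Measured so far in a functional assay on MCF7 cells (Homo sapiens) for antiproliferative activity, read by MTT assay, with a stated time of 72 h; a lower number here means a stronger inhibitor, a higher number a weaker inhibitor:
compound 1 `CCCCc1cn(C[C@H](O)[C@H]2OC(=O)C(OCc3ccccc3)=C2OCc2ccccc2)nn1` – 7910 nM
compound 3 `C[Si](C)(C)c1cn(C[C@H](O)[C@H]2OC(=O)C(OCc3ccccc3)=C2OCc2ccccc2)nn1` – 12100 nM
compound 2 `O=C1O/C(=C\Cn2cc(-c3cc(C(F)(F)F)cc(C(F)(F)F)c3)nn2)C(OCc2ccccc2)=C1OCc1ccccc1` – the reported value is a limit of this assay, > 100000 nM

Compound 1 holds the lowest of the two numbers, but the step of a 1.5-fold higher number from compound 1 to compound 3 (0.18 log units; within the scatter) lies within the scatter, so compounds 1 and 3 are not separated. For compound 2 only the limit of > 100000 nM in this assay, at which 1 of the 3 values shown sits, is known.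

Compound 4 `O=C1O[C@H]([C@@H](O)Cn2cc(CCO)nn2)C(OCc2ccccc2)=C1OCc1ccccc1` differs from compound 1 in one place: hydroxy in place of ethyl on a saturated chain carbon, two bonds along the chain from an aromatic carbon. For the measured compounds named here, no measured step touches this chain; the only single change with numbers, a 1.5-fold higher number from compound 1 to compound 3 (0.18 log units; within the scatter), sits on the aromatic carbon and stays within the scatter. A step to a higher number is expected, a 2.5-fold higher number from compound 1 to compound 4 (0.40 log units; beyond the scatter), with wide uncertainty.

For compound 4 the estimate in this assay is 20000 nM, expected between 6000 nM and 70000 nM.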

Compound 4, half-maximal inhibitory concentration: 63400 nM
For compound 4 the middle estimate is 3.2-fold (0.50 log units) below the measured one; measured number inside the range.
By their numbers in this assay, from the lowest: compounds 1 and 3 (each within the scatter of the next); then compound 4. At a limit, above all of these: compound 2.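

In this assay, the aromatic carbon now shows a step beyond the scatter, with butyl replaced by 2-hydroxyethyl: an 8.0-fold higher number from compound 1 to compound 4 (0.90 log units; beyond the scatter). The silicon-bearing group of compound 3 gives the same direction when replaced by 2-hydroxyethyl: a 5.2-fold higher number from compound 3 to compound 4 (0.72 log units; beyond the scatter). So this position is not indifferent to its group, although the swap of carbon for silicon left compounds 1 and 3 unseparated, and no measurement shown accounts for the step. Open, going by these compounds, is how an amine or a carboxylic acid at the chain end would read here. Also open, on these data alone, is whether a longer chain ending in hydroxy would read like compound 4.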